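The source may hold more compounds than are shown below. What is called first, only, known or untested is meant among the compounds shown, and "the series" means these compounds.

Working notes on the amide series. All three measured compounds share the core of compound 3 `Cc1ccc(C(=O)NCc2ccc(CNS(=O)(=O)c3ccccc3)cc2)cc1` and differ only in the aryl group on the carbonyl carbon. In an assay on MDA-MB-231 cells for binding affinity to C-X-C chemokine receptor type 4 (Homo sapiens), read by immunofluorescence and microscopy, with stated times of 10 min and 30 min (on this read-out higher numbers stand for an effect only at larger amounts of compound and lower numbers for an effect already at smaller amounts), compound 1 `O=C(NCc1ccc(CNS(=O)(=O)c2ccccc2)cc1)c1ccccc1Cl` gives 10 nM. Compound 2 `Cc1cccc(C(=O)NCc2ccc(CNS(=O)(=O)c3ccccc3)cc2)c1` gives 1000 nM in this assay. Compound 3 gives 100 nM in this assay, the second highest of the three numbers: the nearest is compound 1, with a 10-fold higher number from compound 1 to compound 3 (1.00 log units; beyond the scatter), and the furthest is compound 2, with a 10-fold lower number from compound 2 to compound 3 (1.00 log units; beyond the scatter).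

Compound 4 `Cc1ccccc1C(=O)NCc1ccc(CNS(=O)(=O)c2ccccc2)cc1` is not yet measured. It differs from compound 3 by 2-methylphenyl in place of 4-methylphenyl on a carbonyl carbon. For the measured compounds named here, the steps that bear on this are a 10-fold higher number from compound 1 to compound 3 (1.00 log units; beyond the scatter) and a 100-fold higher number from compound 1 to compound 2 (2.00 log units; beyond the scatter): both show the 2-chlorophenyl of compound 1 well ahead of 3-methylphenyl and 4-methylphenyl, and 2-methylphenyl differs from 2-chlorophenyl only in methyl in place of chloro. On the other hand, a 10-fold lower number from compound 2 to compound 3 (1.00 log units; beyond the scatter) shows that moving a methyl group on this phenyl ring can shift the number a good deal in either direction, so the estimate is uncertain. Compound 4 is expected to give 30 nM in this assay, with a likely range of 5 nM to 200 nM. The expected step is a 3.3-fold lower number from compound 3 to compound 4 (0.52 log units; beyond the scatter), moving toward the number of compound 1 rather than beyond it.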

Compound 4, effective concentration (reported as EC, without a stated level of effect): 1 nM
Compound 4: the middle estimate sits 30-fold (1.48 log units) above what was measured; measured number outside the range, below it.
By their numbers in this assay, from the lowest: compound 4; then compound 1; then compound 3; then compound 2.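

Among the three methylphenyl amides, the place of the one methyl group alone spans the whole range in this assay, with a 1000-fold lower number from compound 2 to compound 4 (3.00 log units; beyond the scatter) and a 100-fold lower number from compound 3 to compound 4 (2.00 log units; beyond the scatter), although the atoms are the same and only joined differently. The earlier compounds shown here could not show whether the chloro of the 2-chlorophenyl was needed for its low number, and a 10-fold lower number from compound 1 to compound 4 (1.00 log units; beyond the scatter) now shows that methyl in place of chloro on this aromatic carbon keeps the low number and takes it lower still. The 2-methylphenyl of compound 4 and the 2-chlorophenyl of compound 1 give the two lowest numbers of the four, while 4-methylphenyl in compound 3 and 3-methylphenyl in compound 2 stay well behind them.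

No measurement shown here accounts for why the place of the methyl group matters so much. On these data alone, whether 2-ethylphenyl, 2-methoxyphenyl or plain unsubstituted phenyl on the carbonyl carbon would stay with compound 4 and compound 1 or fall back toward compound 3 remains open, as does what a second methyl group on the same ring would do.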